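Adding a second methoxy group to compound 2

The compounds below may be only part of what the source reports. "The series", "measured", "known", "first", "only" and "open" are said of these compounds alone.

Compound 1, `COc1ccc(-c2cc(C(=O)Nc3nc4ccccc4s3)nc3cc(-c4ccccc4)nn23)cc1OC`, in a functional assay on ACHN cells (Homo sapiens) for cytotoxicity, read by MTT assay, with a stated time of 48 h (a lower number here means a stronger inhibitor, a higher number a weaker inhibitor), gives 7940 nM.
Compound 2, `COc1ccc(-c2cc(C(=O)Nc3nc4cc(C)c(C)cc4s3)nc3cc(-c4ccccc4)nn23)cc1`, in this assay gives 22400 nM.

Of the two measured compounds, compound 2 has the higher number in this assay, and its distance from compound 1 is beyond the usual scatter. The two compounds differ in more than one place, so no single change can be held responsible for the gap between them.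

Compound 3, `COc1ccc(-c2cc(C(=O)Nc3nc4cc(C)c(C)cc4s3)nc3cc(-c4ccccc4)nn23)cc1OC`, is the next compound. Compound 3 differs from compound 2 by methoxy in place of hydrogen on an aromatic carbon, so that the whole change reads as 4-methoxyphenyl to 3,4-dimethoxyphenyl while the rest of compound 2 is kept. Compound 3 thus carries the same 3,4-dimethoxyphenyl group as compound 1 together with the dimethyl-substituted part of compound 2.

Within the data shown here, no single step between measured compounds isolates this change. The expectation for compound 3 is a modest move toward a lower number in this assay, roughly a 1.7-fold lower number from compound 2 to compound 3 (0.24 log units; within the scatter), partly because compound 1, which also carries the 3,4-dimethoxyphenyl group, gives 7940 nM. The estimated value for compound 3 in this assay is 13000 nM, with a range from 5000 nM to 32000 nM.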

Compound 3, half-maximal inhibitory concentration: 8700 nM
For compound 3 the middle estimate is 1.5-fold (0.17 log units) above the measured one, within the range that was stated.
By their numbers in this assay, from the lowest: compounds 1 and 3 (each within the scatter of the next); then compound 2.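

In this assay, among these compounds, methoxy in place of hydrogen on an aromatic carbon, which turns 4-methoxyphenyl into 3,4-dimethoxyphenyl, gives a 2.6-fold lower number from compound 2 to compound 3 (0.41 log units; beyond the scatter), the first step that isolates this position, and it lies beyond the scatter. The second step, 5,6-dimethyl-1,3-benzothiazol-2-yl in place of 1,3-benzothiazol-2-yl on an amide-type nitrogen with the 3,4-dimethoxyphenyl group kept, gives a 1.1-fold higher number from compound 1 to compound 3 (0.04 log units; within the scatter), so in this pair the change on the amide side does not separate the two compounds, and the gap between compound 1 and compound 2 now lines up with the methoxy change at the other end of the molecule. The compounds shown offer no measurement that explains the methoxy step.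

It remains open whether this position responds to methoxy in particular, as a hydroxy group, an ethoxy group or an amine at this place is not among the compounds shown. Among the compounds shown here, it is also open whether the methoxy step keeps its size with 1,3-benzothiazol-2-yl on the amide-type nitrogen, as compound 1 has no 4-methoxyphenyl counterpart here.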